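Fluoro in place of chloro across two cores

A few compounds are considered here, and "the series" means these few. Any claim that something is new, unique, unknown or untested is made for them only; others in the source may bear on it.

Compound 1 `O=C(O)CCC/C=C\C[C@@H]1[C@H](O)CC[C@H]1NS(=O)(=O)c1ccc(Cl)cc1` is measured in a functional assay (plasma) for inhibition, with Homo sapiens as the target (on this read-out lower numbers stand for stronger inhibition and higher numbers for weaker inhibition), and gives 2200 nM. Compound 2 `O=C(O)CC/C=C\C[C@@H]1[C@@H](NS(=O)(=O)c2ccc(Cl)cc2)CC[C@@H]1O` rests on a different core; the difference between the two cores is not broken down here. In this assay compound 2 gives 1800 nM, and this value and that of compound 1 lie within the scatter of each other. Compound 3 `O=C(O)CC/C=C\C[C@@H]1[C@@H](NS(=O)(=O)c2ccc(F)cc2)CC[C@@H]1O` carries fluoro in place of chloro on an aromatic carbon relative to compound 2. In this assay compound 3 gives 1600 nM; the step of a 1.1-fold lower number from compound 2 to compound 3 (0.05 log units; within the scatter) stays within the scatter. Compound 4 `O=C(O)CCC/C=C\C[C@@H]1[C@H](O)CC[C@H]1NS(=O)(=O)c1ccc(F)cc1` has not yet been measured. It differs from compound 1 by fluoro in place of chloro on an aromatic carbon, the same change, at the same place on the ring, as the measured one between the two other compounds, only set on the core of compound 1. It is expected that compound 4 shows a step of a 1.1-fold lower number from compound 1 to compound 4 (0.04 log units; within the scatter) in this assay, because the measured step of a 1.1-fold lower number from compound 2 to compound 3 (0.05 log units; within the scatter) gave no movement beyond the scatter, while what the other core contributes is not broken down. The estimate for compound 4 is 2000 nM, with a range from 1000 nM to 4000 nM expected.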

Compound 4, half-maximal inhibitory concentration: 6000 nM
Compound 4: middle estimate off by 3.0-fold (0.48 log units), on the low side; measured number above the stated range.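

In this assay, fluoro in place of chloro on the core of compound 1 gives a 2.7-fold higher number from compound 1 to compound 4 (0.44 log units; beyond the scatter), so this step reads as weaker inhibition, and the change does not carry over from one core to the other with the same result: the same change on two cores in this assay, a 1.1-fold lower number (0.05 log units; within the scatter) from compound 2 to compound 3 and a 2.7-fold higher number (0.44 log units; beyond the scatter) from compound 1 to compound 4, 3.1-fold (0.49 log units) apart, beyond the scatter of two such steps

Within these four compounds, the effect of going from 4-chlorophenyl to 4-fluorophenyl therefore depends on the core, and a step read on one core is no safe guide to the other. This rests on a single pair on each core and does not show which part of the difference between the cores is responsible, nor why the two steps part.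

From the compounds shown here alone, it remains open whether bromo, methyl or trifluoromethyl on the same aromatic carbon would also separate the two cores. Going by these compounds, it is also open whether the gap would persist with a longer chain ending in the carboxylic acid.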